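A few compounds are considered here, and "the series" means these few. Any claim that something is new, unique, unknown or untested is made for them only; others in the source may bear on it.

Measured in a functional assay on RAW264.7 cells (Mus musculus) for inhibition, read by Griess assay, with stated times of 2 h and 24 h; a lower number here means a stronger inhibitor, a higher number a weaker inhibitor:

- compound 1 `CC(=O)Oc1ccc(CC[C@@H](O)CC/C=C/c2ccccc2)cc1OC(C)=O`: 1610 nM
- compound 2 `CC(=O)Oc1ccc(CCC(=O)CCCCc2ccccc2)cc1OC(C)=O`: 370 nM
- compound 3 `COc1ccc(/C=C/C=C/C(=O)/C=C/c2cccc(O)c2)c(OC)c1`: 970 nM

Compound 3 sits among these numbers as follows. Its value lies within the usual scatter of the value of compound 1, so the two cannot be told apart. Compound 2 has a lower number, and the gap between compound 3 and compound 2 is beyond the scatter. Compound 3 is therefore a weaker inhibitor than compound 2 in this assay.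

The next compound to consider is compound 4 `COc1ccc(/C=C/C=C/C(=O)/C=C/c2ccc(OC)c(O)c2)c(OC)c1`. Its structure departs from that of compound 3 in one place: methoxy in place of hydrogen on an aromatic carbon. A methoxy takes the place of a hydrogen on an aromatic carbon, ortho to a hydroxy group and para to a large group, so that 3-hydroxyphenyl becomes 3-hydroxy-4-methoxyphenyl.

For the measured compounds named here, no pair of measured compounds differs in one place, so the data show nothing directly about this change. Going by the values given here, the only guide is the narrow spread of the three values, from compound 2 at 370 nM to compound 1 at 1610 nM. The estimated step is a 1.1-fold lower number from compound 3 to compound 4 (0.03 log units; within the scatter), and no change beyond the scatter is expected. For compound 4 the expected value is 900 nM, with an estimated range from 350 nM to 2400 nM.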

Compound 4, half-maximal inhibitory concentration: 550 nM
Compound 4: middle estimate off by 1.6-fold (0.21 log units), on the high side; measured number inside the range.
By their numbers in this assay, from the lowest: compounds 2, 4, 3 and 1 (each within the scatter of the next, the first and the last beyond it).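

In this assay, for the compounds shown here, the step of a 1.8-fold lower number from compound 3 to compound 4 (0.25 log units; within the scatter) is the first comparison here between two compounds that differ in one place only, and it shows that a methoxy can stand on this aromatic carbon, ortho to a hydroxy group and para to a large group, without a change that can be told from the scatter. The 3-hydroxyphenyl of compound 3 and the 3-hydroxy-4-methoxyphenyl of compound 4 therefore cannot be separated in this test, and the added methoxy neither clearly helps nor clearly harms at this position. Nothing measured on these compounds offers an explanation for this result.

Still open, from the compounds shown here alone, is whether this same carbon accepts other groups, such as a fluorine, an ethoxy, a longer alkoxy chain or an amine, since one methoxy says nothing about how those would read. Also open, going by these compounds, is what happens in this assay when the hydroxy group on this ring is itself replaced, for example by a methoxy or a carboxylic acid, while the rest of the structure stays the same.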